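This account rests on a few compounds, and the source may have more. Where it says the series, first, only, none or still open, it means among the compounds named here.

Compounds measured so far:
compound 1, `C=C1C(=O)O[C@@H]2CC(C)=C([C@@H](C)CCCOC(C)=O)[C@H](OC(C)=O)[C@H]12`, 8.69%
compound 2, `C=C1C(=O)O[C@@H]2CC(C)=C([C@@H](C)CCCO)[C@H](O)[C@H]12`, 12.3%
compound 3, `CC(=O)OCCC[C@H](C)C1=C[C@@H]2[C@H](C)C(=O)O[C@@H]2C[C@@]1(C)O`, 6.51%

All three were tested in a functional assay on COLO 205 cells (Homo sapiens) for activation, read by flow cytometry, with a stated time of 24 h, tested at 10 uM; a lower number here means a weaker effect, a higher number a stronger effect of the compound at the concentration tested. Compound 2 gives the highest of the three numbers, yet its place is modest: the gap to compound 1, whose number lies nearest, is within the scatter, and the gap to compound 3, whose number lies furthest away, is within the scatter as well. For the measured compounds named here, on these numbers, then, no compound can be set apart from the others.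

The compound not yet measured is compound 4, `C=C1C(=O)O[C@@H]2CC(C)=C([C@@H](C)CCCO)[C@H](OC(=O)C(C)CC)[C@H]12`. It differs from compound 2 in one place: (sec-butyl)carbonyl in place of hydrogen on an oxygen on a saturated carbon.

Going by the values given here, no pair of measured compounds differs in one place, so there is no measured step to lean on. Compound 1 carries two acetyl groups where compound 2 carries hydroxyls, and the two give numbers within the scatter of each other; this is the only hint available, and it points to little movement in this assay when an acyl group enters.

Compound 4 is therefore expected to give 10%, with a range from 3% to 20%, the expected step of a number 2.3 percentage points lower from compound 2 to compound 4 (within the scatter) being no change beyond the scatter.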

Compound 4, a percentage reported as activity, at one concentration (the size of the read-out at that concentration, not a potency): 5.86%
For compound 4 the middle estimate is 4.1 percentage points above the measured one, within the range that was stated.
By their numbers in this assay, from the lowest: compounds 4, 3, 1 and 2 (each within the scatter of the next).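

In this assay, for the compounds shown here, the change at this oxygen can now be read on its own for the first time: (sec-butyl)carbonyl in place of hydrogen on an oxygen on a saturated carbon gives a step of (a number 6.4 percentage points lower from compound 2 to compound 4 (within the scatter)). The earlier compounds shown here could not show this, as compound 1 differs from compound 2 in more than one place, whereas here the hydroxy to ((sec-butyl)carbonyl)oxy exchange is the only difference and the read-out stays within the scatter. So on this single pair, a branched acyl group of this size on this oxygen brings no change that can be told from repeat variation, and nothing shown here bears on why the step has this size.

The compounds shown leave open whether a different group on this oxygen, such as a benzoyl group, or an amine in place of the oxygen, would take the read-out beyond the scatter. They also leave open how the compounds compare at other concentrations, since a read-out at one concentration is not a potency.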